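A few compounds are considered here, and "the series" means these few. Any claim that something is new, unique, unknown or untested is made for them only; others in the source may bear on it.

Two compounds of the series carry numbers in an assay on microsomes from intestine for inhibition of acyl-CoA:cholesterol acyltransferase (Oryctolagus cuniculus); on this read-out lower numbers stand for stronger inhibition and higher numbers for weaker inhibition. Compound 1 `Cc1cc(C)c(NC(=O)N(Cc2cc(-c3ccccc3)cs2)C2CCCCCC2)c(C)c1` gives 36 nM in this assay. Compound 2 `Cc1cc(C)c(NC(=O)N(Cc2cccc(-c3csc(C)n3)c2)C2CCCCCC2)c(C)c1` gives 180 nM in this assay, the higher of the two numbers; its gap to compound 1 lies beyond the scatter, so compound 2 is the weaker inhibitor of the pair. Among the compounds with values here, compound 1 and compound 2 differ in more than one place, so no single-change step is available as a guide. Compound 3 `Cc1cc(C)c(NC(=O)N(Cc2cccc(-c3nn[nH]n3)c2)C2CCCCCC2)c(C)c1` has not been measured. It differs from compound 2 in one place: 2H-tetrazol-5-yl in place of 2-methyl-1,3-thiazol-4-yl on an aromatic carbon. Within the data shown here, no measured pair shows this change, so its size is not known from the series. The expectation is a moderate further weakening, carried with wide uncertainty. The step from compound 2 to compound 3 is expected to be a 3.3-fold higher number from compound 2 to compound 3 (0.52 log units; beyond the scatter). For compound 3 the estimate in this assay is 600 nM, with a range from 150 nM to 3000 nM.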

Compound 3, half-maximal inhibitory concentration: > 1000 nM
Compound 3 gave a limit, no number; the forecaster's own chance of this, stated with the estimate: 10%; middle value at least 1.6-fold (0.22 log units) from the limit.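

At this position, on an aromatic carbon meta to a large group, the series now has its first single-change step: 2H-tetrazol-5-yl in place of 2-methyl-1,3-thiazol-4-yl gives an at least 5.5-fold higher number from compound 2 to compound 3 (0.74 log units; beyond the scatter). In this assay compound 3 reaches only a limit, > 1000 nM, and not a number. The position therefore does not accept this exchange without a loss beyond the scatter, and the step is known from one side only, because its size stops at the limit: the limit of > 1000 nM in this assay, at which 1 of the 3 values shown sits.

On these data alone, how far the loss extends remains open, as does whether it follows the tetrazole ring itself or the hydrogen-bond donor that enters with it. A methyl on a tetrazole nitrogen, or a carboxylic acid on the same aromatic carbon, would bear on that question.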